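Three Methoxy Groups in Place of One

A few compounds are considered here, and "the series" means these few. Any claim that something is new, unique, unknown or untested is made for them only; others in the source may bear on it.

Three measured compounds share a common core and differ in the length of a linking chain and in the substitution on one aromatic ring. Compound 1 `COc1ccccc1/C=C/C(=O)/C=C/c1ccc(OCc2cn(CCCOc3cc(=O)oc4ccccc34)nn2)c(OC)c1`, compound 2 `COc1ccccc1/C=C/C(=O)/C=C/c1ccc(OCc2cn(CCOc3cc(=O)oc4ccccc34)nn2)c(OC)c1` and compound 3 `COc1ccc(/C=C/C(=O)/C=C/c2ccc(OCc3cn(CCCCCOc4cc(=O)oc5ccccc45)nn3)c(OC)c2)cc1` were all tested in a functional assay on HCT-116 cells (Homo sapiens) for inhibition, read by sulforhodamine B assay, with a stated time of 48 h, tested at 50 uM; on this read-out higher numbers stand for more inhibition of growth at the one concentration tested and lower numbers for less inhibition of growth. In this assay compound 1 gives 53%, compound 2 gives 70%, and compound 3 gives 35%. Compound 2 thus stands highest of the three: compound 1 comes nearest, with a number lower by a margin beyond the scatter, and compound 3 lies furthest, also beyond the scatter. None of these pairs differs in only one place, so no single structural step can be read off from the measured set.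

Compound 4 `COc1cc(/C=C/C(=O)/C=C/c2cc(OC)c(OC)c(OC)c2)ccc1OCc1cn(CCOc2cc(=O)oc3ccccc23)nn1` has not yet been measured. It differs from compound 2 in one place: 3,4,5-trimethoxyphenyl in place of 2-methoxyphenyl on a double-bonded chain carbon bound to a double-bonded chain carbon. For the measured compounds named here, nothing among the measured compounds isolates this particular change, so its direction stays open; a modest step either way, or none beyond the scatter, is as plausible as any other outcome. Compound 4 is therefore expected to give about 60%, within a range from 35% to 85%. The step expected from compound 2 to compound 4 is a number 10 percentage points lower from compound 2 to compound 4 (within the scatter).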

Compound 4, percent growth inhibition at one concentration: 89%
Estimate against measurement, compound 4: 29 percentage points below; measured number above the stated range.
By their numbers in this assay, from the lowest: compound 3; then compound 1; then compound 2; then compound 4.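

In this assay, putting 3,4,5-trimethoxyphenyl in place of 2-methoxyphenyl on a double-bonded chain carbon bound to a double-bonded chain carbon gives a number 19 percentage points higher from compound 2 to compound 4 (beyond the scatter), the first effect in this set that can be traced to one structural change. It shows that growth inhibition at the one concentration tested responds to the aromatic ring at this position, and that the larger group with three methoxy groups is accepted here without a loss; the linking chain and the rest of the molecule stay the same across this pair, so the gain belongs to the ring exchange as a whole. Nothing available explains why this exchange raises the number.

Since the number of methoxy groups and their places on the ring change together, this one pair cannot show which of the three methoxy groups matters, or whether a plain phenyl ring or a ring carrying an amine or a carboxylic acid would do as well. It also leaves open whether 3,4,5-trimethoxyphenyl would bring a similar gain on the longer chains of compound 1 and compound 3.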